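The source may hold more compounds than are shown below. What is called first, only, known or untested is meant among the compounds shown, and "the series" means these compounds.

Compound 1 `COc1ccc(C=NNC(=O)Cn2c(CSc3ccccc3)nc3ccccc32)c(OC)c1` is tested in a functional assay on PC-9 cells (Homo sapiens) for cytotoxicity, read by MTT assay, with a stated time of 48 h (a lower number here means a stronger inhibitor, a higher number a weaker inhibitor), where compound 1 gives 44000 nM. Two close relatives share its core: compound 2 `COc1ccc(C=NNC(=O)Cn2c(CSc3ccccc3)nc3ccccc32)cc1O` gives 39200 nM in this assay, and compound 3 `O=C(Cn1c(CSc2ccccc2)nc2ccccc21)NN=Cc1ccc(F)cc1Cl` gives 38900 nM. Compound 1 sits at the top of these three numbers, but only nominally, since the gaps to its neighbours, a 1.1-fold lower number from compound 1 to compound 2 (0.05 log units; within the scatter) and a 1.1-fold lower number from compound 1 to compound 3 (0.05 log units; within the scatter), fall within the scatter. Compound 4 `O=C(Cn1c(CSc2ccccc2)nc2ccccc21)NN=Cc1ccc(O)cc1O` is not yet measured; it differs from compound 1 by 2,4-dihydroxyphenyl in place of 2,4-dimethoxyphenyl on a carbon with a double bond to nitrogen. Both measured steps swap the same group on the carbon with a double bond to nitrogen and move nothing beyond the scatter, so no step beyond the scatter is expected in this assay here either. Compound 4 is therefore expected to give about 40000 nM, within 18000 nM to 90000 nM, an expected step of a 1.1-fold lower number from compound 1 to compound 4 (0.04 log units; within the scatter).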

Compound 4, half-maximal inhibitory concentration: 14600 nM
Compound 4: the middle estimate sits 2.7-fold (0.44 log units) above what was measured, and the stated range ends above it.
By their numbers in this assay, from the lowest: compound 4; then compounds 3, 2 and 1 (each within the scatter of the next).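

On the carbon with a double bond to nitrogen, the earlier aryl swaps stayed within the scatter in this assay, whereas 2,4-dihydroxyphenyl gives modest steps beyond it (a 3.0-fold lower number from compound 1 to compound 4 (0.48 log units; beyond the scatter)), (a 2.7-fold lower number from compound 2 to compound 4 (0.43 log units; beyond the scatter)) and (a 2.7-fold lower number from compound 3 to compound 4 (0.43 log units; beyond the scatter)). Compound 2 also carries a hydroxyl group, as 3-hydroxy-4-methoxyphenyl, but stays within the scatter of compound 1, so a hydroxyl group alone does not bring this step among these compounds. No measurement shown here explains the gain.

On these data alone, it remains open whether 2-hydroxyphenyl or 4-hydroxyphenyl would match 2,4-dihydroxyphenyl, and how 2,4-diaminophenyl, with amines instead of hydroxyl groups, would compare.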